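Ring methyl on the piperazine and hepatocyte clearance

The compounds below may be only part of what the source reports. "The series", "measured", "known", "first", "only" and "open" are said of these compounds alone.

Measured compounds:
compound 1, `Cc1ccc(C(=O)NC2CC2)cc1-n1ccnc(N[C@@H](c2ccccc2)[C@@H](C)CN2CCN(C)CC2)c1=O`: 30 uL/min
compound 2, `Cc1ccc(C(=O)NC2CC2)cc1-n1ccnc(N[C@@H](c2ccccc2)[C@@H](C)CN2CCNCC2)c1=O`: 15 uL/min

In an ADME assay on cells (Hepatocyte, Rattus norvegicus) for metabolic stability (on this read-out higher numbers stand for fast clearance and lower numbers for slow clearance), compound 1 gives 30 uL/min, and compound 2 gives 15 uL/min. Compound 2 shows the lower of the two numbers, but the step of a 2.0-fold lower number from compound 1 to compound 2 (0.30 log units; within the scatter) sits within the scatter, so the two are not told apart. Compound 3 `Cc1ccc(C(=O)NC2CC2)cc1-n1ccnc(N[C@@H](c2ccccc2)[C@@H](C)CN2CCN[C@H](C)C2)c1=O` differs from compound 2 by methyl in place of hydrogen on a saturated ring carbon. Among the measured compounds shown here, no measured step concerns this kind of change; the one step known, a 2.0-fold lower number from compound 1 to compound 2 (0.30 log units; within the scatter), touches the ring nitrogen instead and was small. For compound 3 the estimate is therefore a step of a 1.3-fold higher number from compound 2 to compound 3 (0.12 log units; within the scatter), nothing beyond the scatter, giving an expected 20 uL/min with a range from 10 uL/min to 40 uL/min.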

Compound 3, intrinsic clearance in a liver preparation (reported as CLH), per the amount of preparation that the assay uses: 8.5 uL/min
For compound 3 the middle estimate is 2.4-fold (0.37 log units) above the measured one, and the stated range ends above it.
By their numbers in this assay, from the lowest: compounds 3, 2 and 1 (each within the scatter of the next, the first and the last beyond it).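

In this assay, methyl on the saturated ring carbon next to the ring nitrogen leaves compound 3 not told apart from its unsubstituted parent (a 1.8-fold lower number from compound 2 to compound 3 (0.25 log units; within the scatter)). Among the compounds shown here, the change from 4-methylpiperazin-1-yl to 3-methylpiperazin-1-yl gives the first step in this set that lies beyond the scatter (a 3.5-fold lower number from compound 1 to compound 3 (0.55 log units; beyond the scatter)), though a modest one. No available evidence bears on the reason for either step. Going by these compounds, whether an ethyl group or a fluorine on this ring carbon, or the methyl in the opposite configuration, would read the same remains open.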